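This account rests on a few compounds, and the source may have more. Where it says the series, first, only, none or still open, it means among the compounds named here.

Values in an ADME assay (liver) for metabolic stability, with Liver microsome (Homo sapiens) as the target, read by LC-MS, using microsomes, with a stated time of 30 min, tested at 4 uM (a higher number here means that more of the compound is left, a lower number that less of the compound is left), for the series:
compound 1 `CCN1CCN(c2nc(C)nc3c2nc(-c2ccccc2Cl)n3CCOC)CC1` gives 31%
compound 2 `Cc1nc(N2CCN(C)CC2)c2nc(-c3ccccc3Cl)n(C3CC3)c2n1` gives 31%
compound 3 `Cc1nc(N2CCN(C)CC2)c2nc(-c3ccccc3C(F)(F)F)n(C3CCOCC3)c2n1` gives 24%

Compound 3 at 24% stands within the usual scatter of both compound 1 and compound 2, so the three values form one band with no order among them.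

Compound 4 `COc1cccc(-c2nc3c(N4CCN(C)CC4)nc(C)nc3n2C2CCOCC2)c1` is not yet measured. Its difference from compound 3 is 3-methoxyphenyl in place of 2-(trifluoromethyl)phenyl on an aromatic carbon with 3-methoxyphenyl in place of 2-(trifluoromethyl)phenyl on an aromatic carbon of a five-membered aromatic ring with 2 nitrogen, next to the ring atom that bears an oxan-4-yl group.

For the measured compounds named here, no two measured compounds differ in one place only, so the series gives no direct size for such a change. Compound 1, compound 2 and compound 3 differ in more than one place and still stay within the scatter of one another, which is a thin guide from so few compounds. The estimate is a number 3 percentage points lower from compound 3 to compound 4 (within the scatter) in this assay and is expected to stay within the scatter, with a slight downward direction at most. For compound 4 the estimated value is 21% with an expected range from 8% to 38%.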

Compound 4, percent of the compound remaining: 40%
Estimate against measurement, compound 4: 19 percentage points below; measured number above the stated range.
By their numbers in this assay, from the lowest: compounds 3, 1, 2 and 4 (each within the scatter of the next, the first and the last beyond it).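

For the compounds shown here, replacing 2-(trifluoromethyl)phenyl with 3-methoxyphenyl on the aromatic carbon next to the ring atom that bears an oxan-4-yl group gives the first single-place step: in this assay it is a number 16 percentage points higher from compound 3 to compound 4 (beyond the scatter). The earlier compounds shown here formed one band and gave no size for any single change, whereas this step shows that the aryl group at this place can move the percent remaining beyond the scatter, with the oxan-4-yl group and the rest of the core held constant. The step is a single pair, and no measurement on hand accounts for it.

The change alters both the substituent and its place on the phenyl ring, so the step cannot be divided between the two; a plain phenyl group, or a phenyl carrying methoxy where compound 3 carries trifluoromethyl, would begin to separate them. As far as these compounds go, it also remains open whether a step of this size would recur with a cyclopropyl or 2-methoxyethyl group in place of the oxan-4-yl group.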